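This account rests on a few compounds, and the source may have more. Where it says the series, first, only, none or still open, it means among the compounds named here.

Compound 2 `O=C1NC(=O)/C(=C/c2ccc(OCCSc3nnc(-c4ccc(Br)cc4)[nH]3)cc2)S1` is the point of departure. In a functional assay on the whole organism (plasma, strain Wistar) with Rattus norvegicus as the target, with a stated time of 15 days, at a dose of 100 mg/kg by the oral route (on this read-out higher numbers stand for a stronger effect at the one dose given and lower numbers for a weaker effect), compound 2 gives 28.5%. For the measured compounds named here, the only other number belongs to compound 1 `Cc1ccc(-c2nnc(SCCOc3ccc(/C=C4\SC(=O)NC4=O)cc3)[nH]2)cc1`, which in this assay gives 29.7%; the two values fall within the scatter of each other, so compound 2 is neither set apart from nor ranked against compound 1 on this read-out. Going by the values given here, the one measured step, a number 1.2 percentage points lower from compound 1 to compound 2 (within the scatter), came from bromo in place of methyl on an aromatic carbon and did not leave the scatter. Among the compounds with values here, compound 3 `COc1ccc(-c2nnc(SCCOc3ccc(/C=C4\SC(=O)NC4=O)cc3)[nH]2)cc1` is not yet measured. methoxy in place of bromo on an aromatic carbon Bromo to methoxy has no direct precedent, but the single comparison available, also on an aromatic carbon, showed no step beyond the scatter. No step beyond the scatter is therefore expected in this assay, as a number 0.5 percentage points higher from compound 2 to compound 3 (within the scatter). For compound 3 the estimate in this assay is 29%, with a range from 18% to 40%.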

Compound 3, a percentage reported as activity, at one dose (the size of the read-out at that dose, not a potency): 43.4%
Beside the measured number, compound 3's estimate is 14.4 percentage points below it; the whole stated range lies below it.
By their numbers in this assay, from the lowest: compounds 2 and 1 (each within the scatter of the next); then compound 3.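

In this assay, this aromatic carbon, para to a large group, proves able to move the read-out: 4-bromophenyl to 4-methoxyphenyl gives a number 14.9 percentage points higher from compound 2 to compound 3 (beyond the scatter) and methoxy in place of methyl gives a number 13.7 percentage points higher from compound 1 to compound 3 (beyond the scatter) on the same core. Methyl and bromo had stayed within the scatter of each other, so the earlier pair gave no sign that the substituent here mattered. Of the three groups shown, methoxy alone is set apart from the other two, both of which it exceeds beyond the scatter.

Still open, from the compounds shown here alone, is whether this gain needs the whole methoxy group or would persist with a hydroxy, an ethoxy, an amine or a carboxylic acid on this carbon. Nothing available gives a reason for the gain seen with methoxy.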